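The source may report more compounds than this note shows. Statements on the series, on what has been measured and on what is new or still open speak of the compounds shown alone.

Three compounds have so far been measured in an assay on CHO cells for displacement of a labelled ligand from prostacyclin receptor (Homo sapiens), read by scintillation counting, with a stated time of 30 min; on this read-out lower numbers stand for stronger inhibition and higher numbers for weaker inhibition:

Compound 1, `COc1cc(C(=O)n2c(C)c(CC(=O)O)c3ccccc32)ccc1OC[C@@H]1CN(C)c2ccccc2O1`: in this assay compound 1 gives 430 nM
Compound 2, `Cc1cc(C(=O)n2c(C)c(CC(=O)O)c3ccccc32)c(C)cc1OC[C@@H]1CN(C)c2ccccc2O1`: in this assay compound 2 gives 94 nM
Compound 3, `Cc1cc(OC[C@@H]2CN(C)c3ccccc3O2)ccc1C(=O)n1c(C)c(CC(=O)O)c2cc(F)ccc21`: in this assay compound 3 gives 130 nM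

Among these three numbers, compound 3 holds the second highest. Its nearest neighbour is compound 2, whose number is lower by a margin that falls within the scatter of repeated measurements, so the two cannot be told apart. Compound 1 stands furthest away, with a number higher than that of compound 3 by a margin beyond the scatter, so compound 1 is the weaker binder of that pair. No two of the measured compounds differ in just one place, so no single-change step can be read from them.

Compound 4, `Cc1c(CC(=O)O)c2cc(F)ccc2n1C(=O)c1ccc(OC[C@@H]2CN(C)c3ccccc3O2)cc1Cl`, has not been measured. It differs from compound 3 by chloro in place of methyl on an aromatic carbon: one heavy atom replaces another on the same aromatic carbon, ortho to a large group and meta to a large group. For the measured compounds named here, no measured step shows what such an exchange does here, so the expectation rests on the exchange itself: a shift no larger than the scatter, in either direction. Compound 4 is therefore expected to give 130 nM in this assay, within a range from 50 nM to 350 nM, which amounts to an expected step of no change at the digits printed from compound 3 to compound 4 (within the scatter).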

Compound 4, inhibition constant: 200 nM
Beside the measured number, compound 4's estimate is 1.5-fold (0.19 log units) below it; low and high end bracket the measured number.
By their numbers in this assay, from the lowest: compounds 2, 3 and 4 (each within the scatter of the next, the first and the last beyond it); then compound 1.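

In this assay the exchange of methyl for chloro on this aromatic carbon, ortho to a large group and meta to a large group, gives a 1.5-fold higher number from compound 3 to compound 4 (0.19 log units; within the scatter) and the two compounds cannot be told apart. For the compounds shown here, this is the only direct reading of this position so far: with the rest of the molecule unchanged, binding reads the same with either group within the scatter. Nothing available explains why these two groups read alike.

Compounds 1 and 2 each differ from compound 3 in more than one place, so they add no further reading of this carbon. As far as these compounds go, it remains open how this position responds to groups unlike these two, such as a bare hydrogen, a methoxy, a nitrile or an amine.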